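Replacing Acetamido With Ethoxy on a Shared Core

The source may hold more compounds than are shown below. What is called first, only, known or untested is meant among the compounds shown, and "the series" means these compounds.

Measured so far:
Compound 1 `CC(=O)Nc1ccc(-c2c(C#N)c(N)nc(SCC(N)=O)c2C#N)cc1`: 164 nM
Compound 2 `N#Cc1c(N)nc(SCc2ncc[nH]2)c(C#N)c1-c1ccc(OCC2CC2)cc1`: 9.5 nM

In a functional assay on CHO cells for agonist activity at adenosine receptor A2b (Homo sapiens), read by AlphaScreen and cAMP accumulation (on this read-out lower numbers stand for an effect already at smaller amounts and higher numbers for an effect only at larger amounts of compound), compound 1 has the higher of the two numbers, while compound 2 gives 9.5 nM, a lower number well beyond the scatter. Compound 3 `CCOc1ccc(-c2c(C#N)c(N)nc(SCC(N)=O)c2C#N)cc1` keeps the core of compound 1 and differs in one place: ethoxy in place of acetamido on an aromatic carbon. Within the data shown here, no measured pair shows this change alone, so the size of its step is unknown. Among the measured compounds shown here, a modest move toward a lower number is expected, a 2.7-fold lower number from compound 1 to compound 3 (0.44 log units; beyond the scatter), since the only other measured compound carries an ether at the same place. Compound 3 is estimated at 60 nM, within 20 nM to 200 nM.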

Compound 3, half-maximal effective concentration: 38 nM
Compound 3: middle estimate off by 1.6-fold (0.20 log units), on the high side, within the range that was stated.
By their numbers in this assay, from the lowest: compound 2; then compound 3; then compound 1.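

In this assay, the group on the aromatic ring can be changed with the rest of compound 1 held fixed: ethoxy in place of acetamido gives a modest move (a 4.3-fold lower number from compound 1 to compound 3 (0.64 log units; beyond the scatter)). The change removes the hydrogen-bond donor of acetamido, and the number still falls, so that donor is not needed for an effect at low amounts on this core. No measurement here explains the size of this step. Going by these compounds, it remains open whether a longer chain such as butoxy, or a simple amine, would lower the number further or raise it.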